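A few compounds are considered here, and "the series" means these few. Any claim that something is new, unique, unknown or untested is made for them only; others in the source may bear on it.

Within the data shown here, compound 2 `C/C=C/C(=O)Nc1cccc(Oc2nc(Nc3cccc(C#N)c3)nc3ccsc23)c1` gives 33100 nM in a functional assay on MCF7 cells (Homo sapiens) for inhibition, read by MTT assay, with a stated time of 72 h (a higher number here means a weaker inhibitor, a lower number a stronger inhibitor), the only plain number available here. Compound 1 `COc1ccc(Nc2nc(Oc3cccc(NC(=O)/C=C/C(C)C)c3)c3sccc3n2)cn1` gives > 50000 nM in this assay, which is a limit of the assay and not a number. Compound 3 `CC(C)/C=C/C(=O)Nc1cccc(Oc2nc(Nc3cccc(C#N)c3)nc3ccsc23)c1` differs from compound 2 by a single change: isopropyl in place of methyl on a double-bonded chain carbon bound to a double-bonded chain carbon. No measured step of this kind exists among these compounds, so only a small expected step, a 1.4-fold higher number from compound 2 to compound 3 (0.13 log units; within the scatter), is estimated, leaning toward weaker inhibition. Compound 3 is estimated at 45000 nM, with a range from 15000 nM to 150000 nM.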

Compound 3, half-maximal inhibitory concentration: > 50000 nM
Compound 3 gave a limit, no number; the forecaster's own chance of this, stated with the estimate: 40%; middle value at least 1.1-fold (0.04 log units) from the limit.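

Compound 3 reads as a limit of the assay in this assay, not as a number. Isopropyl in place of methyl on this chain carbon therefore gives only a floor, an at least 1.5-fold higher number from compound 2 to compound 3 (0.17 log units; that floor lies within the scatter), and no stronger inhibition appears with this change. The step from compound 1 to compound 3 cannot be read, as both values are limits.

Going by these compounds, how far compound 3 truly lies past its limit stays open, as does whether a smaller hydrogen or a dimethylamino group at this place would give a plain number. The readings crowd at one ceiling: the limit of > 50000 nM in this assay, at which 2 of the 3 values shown sit.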